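The compounds below may be only part of what the source reports. "The series", "measured", "known", "first", "only" and "open" are said of these compounds alone.

Three urea compounds share one core and have been measured in a functional assay (thoracic aorta, Rattus norvegicus, strain Wistar); on this read-out lower numbers stand for an effect already at smaller amounts and higher numbers for an effect only at larger amounts of compound. Compound 1 `O=C(Nc1nc2ccc(Br)cc2s1)Nc1ccc(C(F)(F)F)cc1Cl` carries a bromo group on that core; in this assay compound 1 gives only a limit, > 100000 nM (the limit of > 100000 nM in this assay, at which 1 of the 3 values shown sits). Compound 2 `CC(C)NC(=O)Nc1nc2ccc([N+](=O)[O-])cc2s1` carries a nitro group and an isopropyl urea, and in this assay compound 2 gives 15700 nM. Compound 3 `O=C(Nc1nc2ccc([N+](=O)[O-])cc2s1)Nc1ccc(C(F)(F)F)cc1Cl` keeps the aryl urea of compound 1 but has nitro in place of bromo; in this assay compound 3 gives 54300 nM, the highest of the two numbers shown, with compound 2 standing lower. Within the data shown here, the one measured step, an at least 1.8-fold lower number from compound 1 to compound 3 (0.26 log units; that floor lies within the scatter), is a swap of one group for another at the same place and rests on a limit.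

Compound 4 `O=C(Nc1nc2ccccc2s1)Nc1ccc(C(F)(F)F)cc1Cl` differs from compound 3 by hydrogen in place of nitro on an aromatic carbon. Among the measured compounds shown here, no measured step removes a group outright, so the direction is uncertain; the expected step of a 1.5-fold higher number from compound 3 to compound 4 (0.17 log units; within the scatter) is small. Compound 4 is estimated at 80000 nM, within 20000 nM to 300000 nM.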

Compound 4, half-maximal effective concentration: > 100000 nM
Compound 4: a limit, no number; the forecaster's own chance of this, stated with the estimate: 40%; middle value at least 1.2-fold (0.09 log units) away from the limit.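

Among these compounds, this result is the first look at this position with no substituent, only hydrogen. In this assay, hydrogen in place of nitro gives an at least 1.8-fold higher number from compound 3 to compound 4 (0.26 log units; that floor lies within the scatter). Among the aryl ureas shown, only compound 3 gives a number, although the floor of that step cannot be told apart from the usual scatter. Compound 4, like compound 1, gives a limit and not a number: the limit of > 100000 nM in this assay, at which 2 of the 4 values shown sit.

The step between compound 1 and compound 4 cannot be read, with a limit on both sides. Still open, from the compounds shown here alone, is whether an amine, a carboxylic acid or a nitrile at this place would give a measurable number, and whether the isopropyl urea of compound 2 would keep a number with hydrogen in place of nitro.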